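This account rests on a few compounds, and the source may have more. Where it says the series, first, only, none or still open, it means among the compounds named here.

In a small set of three compounds, compound 1 (`O=C(NCc1ccc(F)cc1)c1nc(NCCO)c2cccnc2c1O`) gives 91000 nM in a toxicity assay on C8166 cells (Homo sapiens) for cytotoxicity, read by MTT assay, with a stated time of 72 h (on this read-out lower numbers stand for higher toxicity in this test and higher numbers for lower toxicity in this test), and holds the lower of the two numbers available. Compound 2 (`O=C(NCc1ccc(F)cc1)c1nc(Br)c2cccnc2c1NCCO`) stands at 232000 nM in this assay and lies above compound 1 by a gap beyond the usual scatter of repeats. Compound 3 (`C[C@H](Nc1c(C(=O)NCc2ccc(F)cc2)nc(Br)c2cccnc12)c1ccccc1`) offers no number: its entry reads "not determined" (no result reported) and adds nothing to the comparison.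

Compound 4 (`C[C@H](CO)Nc1nc(C(=O)NCc2ccc(F)cc2)c(O)c2ncccc12`) has not yet been measured. It keeps the core of compound 1, but its 2-hydroxyethyl becomes 1-(hydroxymethyl)ethyl: methyl in place of hydrogen on a saturated chain carbon bound to a nitrogen on an aromatic ring and a saturated chain carbon. This places methyl in place of hydrogen on a saturated chain carbon bound to a nitrogen on an aromatic ring and a saturated chain carbon.

Going by the values given here, no two measured compounds differ in one place, so no measured step speaks directly to this change. Among the compounds with values here, the only close reference is compound 1 at 91000 nM and no shift beyond the scatter is expected in this assay, with no direction favoured. The estimated change is a 1.1-fold higher number from compound 1 to compound 4 (0.04 log units; within the scatter) and is expected to stay within that scatter. Compound 4 is expected at 100000 nM with an estimated range from 45000 nM to 220000 nM.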

Compound 4, half-maximal cytotoxic concentration: 69000 nM
For compound 4 the middle estimate is 1.4-fold (0.16 log units) above the measured one; low and high end bracket the measured number.
By their numbers in this assay, from the lowest: compounds 4 and 1 (each within the scatter of the next); then compound 2.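

The first step measured at this position shows that, in this assay, methyl in place of hydrogen on a saturated chain carbon bound to a nitrogen on an aromatic ring and a saturated chain carbon gives a 1.3-fold lower number from compound 1 to compound 4 (0.12 log units; within the scatter) and so stays within the scatter. Going by these compounds alone, on the core of compound 1, the 2-hydroxyethyl and 1-(hydroxymethyl)ethyl chains therefore cannot be told apart on this read-out, something the earlier compounds could not show because no two of them differed in one place. No further data shown bear on this result.

This single step says nothing about how larger changes at this position would read, such as a longer chain, a carboxylic acid or an amine in place of the terminal hydroxyl. It also leaves open whether the same methyl would read the same way on a different core, such as that of compound 2, which carries bromine and has its groups arranged differently.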